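The source may hold more compounds than are shown below. What is called first, only, known or untested is meant among the compounds shown, and "the series" means these compounds.

Of the compounds shown here, two of the same core have been measured in an assay on isolated protein for inhibition of aldehyde dehydrogenase 1A1 (Homo sapiens); a lower number here means a stronger inhibitor, a higher number a weaker inhibitor. Compound 1, `Cn1ncc2c(=O)n(-c3ccccc3)c(COc3cccc(F)c3)nc21`, gives 8200 nM, the higher of the two numbers recorded. Within the data shown here, compound 2, `CCC(Sc1nc2c(cnn2C)c(=O)n1-c1ccccc1)c1ccccc1`, gives 150 nM in this assay, so compound 1 stands at the weak end of what has been seen so far, with compound 2 as its only neighbour and that neighbour well beyond the scatter from it. Compound 2 differs from compound 1 in more than one place, so what separates them cannot be tied to a single change.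

Compound 3, `Cn1ncc2c(=O)n(-c3ccccc3)c(CCc3cccc(F)c3)nc21`, has not yet been measured. It differs from compound 1 in one place: 3-fluorobenzyl in place of 3-fluorophenoxy on a saturated chain carbon bound to an aromatic carbon. Among the measured compounds shown here, no step between two measured compounds covers a change of this kind, so nothing in the present numbers points in either direction. The expected step from compound 1 to compound 3 in this assay is therefore a 1.2-fold lower number from compound 1 to compound 3 (0.07 log units; within the scatter), none beyond the scatter. Compound 3 is accordingly estimated at 7000 nM, with a plausible range from 1800 nM to 27000 nM.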

Compound 3, half-maximal inhibitory concentration in the aldehyde dehydrogenase 1A1 assay: 1000 nM
The estimate for compound 3 lay 7.0-fold (0.85 log units) above the measured number; measured number outside the range, below it.
By their numbers in the aldehyde dehydrogenase 1A1 assay, from the lowest: compound 2; then compound 3; then compound 1.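

Among these compounds, in the aldehyde dehydrogenase 1A1 assay, compound 1 gives 8200 nM and compound 3 gives 1000 nM; putting 3-fluorobenzyl in place of 3-fluorophenoxy on a saturated chain carbon bound to an aromatic carbon gives an 8.2-fold lower number from compound 1 to compound 3 (0.91 log units; beyond the scatter), the first step in this set that can be tied to a single change, and it shows that this position does respond to the change. The two groups match in heavy-atom count and each carries one six-membered aromatic ring of carbon only, while the group that leaves holds an oxygen and a hydrogen-bond acceptor and the group that enters holds neither. In a physicochemical assay for solubility, using the shake flask method, in phosphate buffer, with a stated time of 24 h, at pH 7.4 (a lower number here means a less soluble compound, a higher number a more soluble compound), compound 1 gives 194000 nM and compound 3 gives 126000 nM. In the physicochemical assay, the same change gives a 1.5-fold lower number from compound 1 to compound 3 (0.19 log units; within the scatter), so the pair separates in one read-out and not in the other, and nothing measured here accounts for the step.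

The compounds shown leave open whether an amine at this place, or a longer chain carrying the same ring, would give a number nearer that of compound 3 or that of compound 1. They also leave open whether the step keeps its size on an unsubstituted phenyl ring, without the fluorine.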